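Morpholin-4-yl for Pyrrolidin-1-yl on the Thiocarbonyl Carbon

The compounds below may be only part of what the source reports. "The series", "measured", "known", "first", "only" and "open" are said of these compounds alone.

Measured so far in a functional assay on A-375 cells (Homo sapiens) for cytotoxicity, read by MTT assay, with a stated time of 72 h, tested at 10 uM; on this read-out lower numbers stand for less inhibition of growth and higher numbers for more inhibition of growth at the one concentration tested:
compound 1 `Cc1ccnc(/C(N)=N/NC(=S)N2CCCC2)c1` gives 86%
compound 2 `N/C(=N\NC(=S)N1CCOCC1)c1ccc(F)cn1` gives 70.3%
compound 3 `N/C(=N\NC(=S)N1CCCCCC1)c1ccccn1` gives 86.5%

Compound 1 stands second highest of the three numbers. Its value and that of compound 3 lie within the scatter of each other, so no order between them is claimed; compound 2 sits beyond the scatter below compound 1. Compound 4 `Cc1ccnc(/C(N)=N/NC(=S)N2CCOCC2)c1` has not been measured. It differs from compound 1 in one place: morpholin-4-yl in place of pyrrolidin-1-yl on a thiocarbonyl carbon. Going by the values given here, no step between measured compounds isolates this change. Compound 2 also carries morpholin-4-yl but differs from compound 1 elsewhere as well, so its value is only a weak pointer. In this assay a small drop, around the edge of the scatter, is expected: a number 9 percentage points lower from compound 1 to compound 4 (within the scatter). Compound 4 is estimated at 77%, between 62% and 90%.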

Compound 4, percent growth inhibition at one concentration: 86%
Beside the measured number, compound 4's estimate is 9 percentage points below it, within the range that was stated.
By their numbers in this assay, from the lowest: compound 2; then compounds 1, 4 and 3 (each within the scatter of the next).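

In this assay, going by these compounds alone, morpholin-4-yl in place of pyrrolidin-1-yl on a thiocarbonyl carbon gives no change at the digits printed from compound 1 to compound 4 (within the scatter), the first reading of this change on a single core. On the core of compound 1, this position therefore accepts either ring at the one concentration tested, and morpholin-4-yl alone brings no lower number. Nothing available explains this result.

Open, from the compounds shown here alone, is whether an open-chain dimethylamino group or a piperazin-1-yl ring on the thiocarbonyl carbon would read the same. Also open, going by these compounds, is whether the two rings would still match at lower concentrations.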